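The source may report more compounds than this note shows. Statements on the series, on what has been measured and on what is new or still open speak of the compounds shown alone.

Of the compounds shown here, three of a shared core have been measured in an assay on isolated protein for inhibition of long-chain fatty acid transport protein 1 (Homo sapiens), read by scintillation counting, with a stated time of 20 min; on this read-out lower numbers stand for stronger inhibition and higher numbers for weaker inhibition. Compound 1 `O=C(CN1CCN(c2ccc(F)cc2)CC1)Nc1nc2c(s1)CCCC2` gives 77 nM and compound 2 `O=C(CN1CCN(c2ccc(F)cc2)CC1)Nc1nc2c(s1)CCCCC2` gives 120 nM. Compound 3 `Cc1ccc(N2CCN(CC(=O)Nc3nc4c(s3)CCCC4)CC2)cc1` gives 250 nM, which is the highest of the three numbers; its distance from compound 2 and from compound 1 both lie beyond the scatter. The one single-point step among these is a 3.2-fold higher number from compound 1 to compound 3 (0.51 log units; beyond the scatter), and this is the step that sets compound 3 apart.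

Compound 4 `O=C(CN1CCN(c2ccccn2)CC1)Nc1nc2c(s1)CCCC2` differs from compound 3 by one change: pyridin-2-yl in place of 4-methylphenyl on an amine nitrogen in a ring. For the measured compounds named here, no measured pair shows this exact change, so the expectation rests on the step from compound 1 to compound 3, in which the aromatic group on the amine nitrogen was the only thing altered and the number rose. Removing the methyl and bringing in a ring with one hetero atom is a further change of the same group. Compound 4 is therefore expected to move back toward the numbers of compound 1 and compound 2 rather than further up, with the step of a 2.3-fold lower number from compound 3 to compound 4 (0.36 log units; beyond the scatter) expected to be modest. The estimate for compound 4 in this assay is 110 nM, with a range from 35 nM to 350 nM.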

Compound 4, half-maximal inhibitory concentration: 200 nM
Beside the measured number, compound 4's estimate is 1.8-fold (0.26 log units) below it; low and high end bracket the measured number.
By their numbers in this assay, from the lowest: compounds 1, 2, 4 and 3 (each within the scatter of the next, the first and the last beyond it).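

On the amine nitrogen in the ring, pyridin-2-yl in place of 4-methylphenyl gives a 1.3-fold lower number from compound 3 to compound 4 (0.10 log units; within the scatter), so in this assay compound 3 and compound 4 cannot be told apart, although the entering group has a ring with 1 hetero atom and 1 hydrogen-bond acceptor where the leaving group has none. For the compounds shown here, measured from the 4-fluorophenyl of compound 1, the change to pyridin-2-yl is a 2.6-fold higher number from compound 1 to compound 4 (0.41 log units; beyond the scatter) and the change to 4-methylphenyl is a 3.2-fold higher number from compound 1 to compound 3 (0.51 log units; beyond the scatter), which leaves 4-fluorophenyl as the one group of these three that stands apart at this position. Nothing available accounts for this outcome.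

The compounds shown leave open whether other groups on this amine nitrogen, such as plain phenyl, 4-chlorophenyl or pyridin-4-yl, would fall with 4-fluorophenyl or with the other two. They also leave open whether pyridin-2-yl and 4-fluorophenyl would stand in the same relation on the core of compound 2.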